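From Vinyl to 1-Methylcyclopropyl on an Aromatic Nitrogen

A few compounds are considered here, and "the series" means these few. Any claim that something is new, unique, unknown or untested is made for them only; others in the source may bear on it.

Compound 1 `CCn1cc(C(=O)O)c(=O)c2cc(F)c(N3CCC(N)C3)c(F)c21`: 300 ug/mL
Compound 2 `C=Cn1cc(C(=O)O)c(=O)c2cc(F)c(N3CCC(N)C3)c(F)c21`: 310 ug/mL

Both compounds were tested in a functional assay on V79 cells (Cricetulus griseus) for cytotoxicity, read by colony formation; a higher number here means a weaker inhibitor, a lower number a stronger inhibitor. Compound 2, at 310 ug/mL, stands level with compound 1, at 300 ug/mL, and neither can be ranked above the other. Among the measured compounds shown here, the one measured step, with vinyl in place of ethyl on an aromatic nitrogen, is a 1.0-fold higher number from compound 1 to compound 2 (0.01 log units; within the scatter).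

Compound 3 `CC1(n2cc(C(=O)O)c(=O)c3cc(F)c(N4CCC(N)C4)c(F)c32)CC1` has not yet been measured. It carries 1-methylcyclopropyl in place of vinyl on that same aromatic nitrogen: 1-methylcyclopropyl in place of vinyl on an aromatic nitrogen. For the measured compounds named here, the step from compound 1 to compound 2 is the only evidence at this place, and it offers limited guidance. Going by the values given here, it involves two open groups, and no measured compound has a ring there. Nothing measured sets a firm direction, so only a slight lean towards a lower number in this assay is expected, with no shift beyond the scatter. The expected change is a 1.4-fold lower number from compound 2 to compound 3 (0.15 log units; within the scatter). The estimate for compound 3 is 220 ug/mL, expected to fall between 80 ug/mL and 450 ug/mL.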

Compound 3, half-maximal inhibitory concentration: 160 ug/mL
For compound 3 the middle estimate is 1.4-fold (0.14 log units) above the measured one; the measured number falls inside the stated range.
By their numbers in this assay, from the lowest: compounds 3, 1 and 2 (each within the scatter of the next).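

Compound 3 brings the first ring onto this aromatic nitrogen, the three-membered non-aromatic ring of carbon only in 1-methylcyclopropyl, and in this assay the change from vinyl gives a 1.9-fold lower number from compound 2 to compound 3 (0.29 log units; within the scatter) while the change from ethyl gives a 1.9-fold lower number from compound 1 to compound 3 (0.27 log units; within the scatter) so that neither step leaves the scatter. Replacing vinyl, with its 2 heavy atoms and double bond, by a group of 4 heavy atoms holding a ring therefore does not separate compound 3 from compound 2 or compound 1, and the three groups cannot be ranked on these numbers. No measurement is available that would explain the values at this position.

The step to compound 3 brings in the ring and its methyl together, so the compounds shown cannot tell what each contributes, and plain cyclopropyl on this nitrogen would be needed to part them. Going by these compounds, whether a phenyl ring, a tert-butyl group or a longer chain ending in a hydroxyl group at this place would move the number beyond the scatter also stays open.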